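Cytotoxicity notes: arylsulfanyl replacing the piperazine in the series

The source may hold more compounds than are shown below. What is called first, only, known or untested is meant among the compounds shown, and "the series" means these compounds.

Four compounds share a common core. Compound 1 `Cc1cc(N2CCCC2)cn2c(CSCCc3ccccc3)cnc12` and compound 2 `Cc1cc(Sc2ccc(N)cc2)cn2c(CSCCc3ccccc3)cnc12` have been measured in an ADME assay on HEL cells (Homo sapiens) for cytotoxicity, with a stated time of 3 days; a higher number here means that more compound is tolerated, a lower number that less compound is tolerated; compound 3 `Cc1cc(N2CCN(C)CC2)c2ncc(CSCCc3ccccc3)n2c1` has no result there, and compound 4 `Cc1cc(Sc2ccc(Cl)cc2)c2ncc(CSCCc3ccccc3)n2c1` is still to be measured.

In this assay compound 1 gives 20 ug/mL. In this assay compound 2 gives 20 ug/mL. Within the data shown here, the one measured step, no change at the digits printed from compound 1 to compound 2 (within the scatter), is the only comparison available. For compound 3 the entry in this assay reads "not determined" (no result reported), so there is no number to stand on for that compound.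

The change from compound 3 to compound 4 is (4-chlorophenyl)sulfanyl in place of 4-methylpiperazin-1-yl on an aromatic carbon. Among the measured compounds shown here, no measured step covers this exact exchange. The nearest information is the step from compound 1 to compound 2, in which a sulfanyl-linked aromatic group entered at the same kind of position without a change beyond the scatter in this assay. Both measured compounds sit at the same tolerated concentration, so the expectation for compound 4 is a value close to theirs rather than a large move in either direction.

For compound 4 the tolerated concentration in this assay is therefore estimated at 20 ug/mL, with a range from 4 ug/mL to 100 ug/mL.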

Compound 4, minimum cytotoxic concentration: 4 ug/mL
Compound 4: middle estimate off by 5.0-fold (0.70 log units), on the high side, and the stated range covers the measured number.
By their numbers in this assay, from the lowest: compound 4; then compounds 1 and 2 (each within the scatter of the next).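

Among these compounds, compound 3 has no single number in this assay, so the value of compound 4, 4 ug/mL, gives no step that can be read between the two. Going by these compounds, what (4-chlorophenyl)sulfanyl in place of 4-methylpiperazin-1-yl does to the tolerated concentration on this core stays open. No supporting data bear on the result for compound 4.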